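The compounds below may be only part of what the source reports. "The series", "measured", "known", "first", "only" and "open" are said of these compounds alone.

Compound 1 `CC1=CC[C@H](C(C)(C)NC(=S)N/N=C/c2ccccc2)CC1` gives 8800 nM in a functional assay on HT-29 cells (Homo sapiens) for inhibition, read by sulforhodamine B assay, with a stated time of 48 h; a higher number here means a weaker inhibitor of growth, a lower number a stronger inhibitor of growth. Compound 2 `CC1=CC[C@H](C(C)(C)NC(=S)N/N=C/c2cccc(Cl)c2)CC1`, the same core with chloro in place of hydrogen on an aromatic carbon, gives 7900 nM in this assay; the step of a 1.1-fold lower number from compound 1 to compound 2 (0.05 log units; within the scatter) shows that compound 2 and compound 1 sit within the scatter of each other. Compound 3 `CC1=CC[C@H](C(C)(C)NC(=S)N/N=C/c2cccc([N+](=O)[O-])c2)CC1` differs from compound 2 by nitro in place of chloro on an aromatic carbon. Among the measured compounds shown here, the only measured step, a 1.1-fold lower number from compound 1 to compound 2 (0.05 log units; within the scatter), changed a substituent at this same position without moving the number, so no step beyond the scatter is expected in this assay, as a 1.0-fold higher number from compound 2 to compound 3 (0.01 log units; within the scatter) states. Compound 3 is expected to give 8000 nM, ranging from 3500 nM to 18000 nM.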

Compound 3, concentration for 50% growth inhibition: 600 nM
Beside the measured number, compound 3's estimate is 13-fold (1.12 log units) above it; measured number below the stated range.
By their numbers in this assay, from the lowest: compound 3; then compounds 2 and 1 (each within the scatter of the next).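

This position is not indifferent in this assay: hydrogen and chloro sit within the scatter of each other, yet nitro brings a 13-fold lower number from compound 2 to compound 3 (1.12 log units; beyond the scatter) and also a 15-fold lower number from compound 1 to compound 3 (1.17 log units; beyond the scatter). The flat first step therefore held for chloro only, and not for every group placed here. Nothing shown gives a reason for this large change.

Still open, on these data alone, is whether nitro alone does this, or whether a nitrile or an amine at this place would do the same. Also open, as far as these compounds go, is how nitro would behave elsewhere on the ring.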